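Thiadiazole to pyrimidine on the sulfur of compound 3

A few compounds are considered here, and "the series" means these few. Any claim that something is new, unique, unknown or untested is made for them only; others in the source may bear on it.

Measured compounds:
compound 1 `Cc1nnc(SCC(=O)N/N=c2/scc(-c3ccc(Cl)cc3)n2-c2ccccc2)s1` gives 76.6%
compound 2 `O=C(CSc1ncccn1)N/N=c1/scc(-c2ccc(Br)cc2)n1-c1ccccc1` gives 72.1%
compound 3 `COc1ccc(-c2cs/c(=N/NC(=O)CSc3nnc(C)s3)n2-c2ccccc2)cc1` gives 53.6%

In a functional assay on C6 cells (Rattus norvegicus) for cytotoxicity, read by MTT assay, with a stated time of 24 h, tested at 12 ug/mL (on this read-out lower numbers stand for a stronger effect and higher numbers for a weaker effect at the one concentration tested), compound 3 stands lowest of the three numbers; compound 2 lies nearest, and compound 1 furthest, both beyond the scatter. Compound 4 `COc1ccc(-c2cs/c(=N/NC(=O)CSc3ncccn3)n2-c2ccccc2)cc1` differs from compound 3 by pyrimidin-2-yl in place of 5-methyl-1,3,4-thiadiazol-2-yl on a sulfur. Within the data shown here, the only one-place step known, a number 23 percentage points lower from compound 1 to compound 3 (beyond the scatter), concerns the methoxy-for-chloro exchange and not the change made here. Compounds 1 and 2 carry the two heterocycles in question, but they also differ in their halogen, so their two values show only that both lie well above compound 3. Among the measured compounds shown here, with no step bearing directly on this change, compound 4 is expected to remain close to compound 3, with a number 2.4 percentage points higher from compound 3 to compound 4 (within the scatter) not beyond the scatter, and an estimated value of 56%, ranging from 40% to 74%.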

Compound 4, a percentage reported as activity, at one concentration (the size of the read-out at that concentration, not a potency): 78.4%
The estimate for compound 4 lay 22.4 percentage points below the measured number; the measured number lies above the stated range.
By their numbers in this assay, from the lowest: compound 3; then compounds 2, 1 and 4 (each within the scatter of the next).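

In this assay, the group on the sulfur matters when methoxy is held constant: pyrimidin-2-yl in place of 5-methyl-1,3,4-thiadiazol-2-yl gives a number 24.8 percentage points higher from compound 3 to compound 4 (beyond the scatter), so the stronger effect of compound 3 is lost. With pyrimidin-2-yl held constant, methoxy in place of bromo gives a number 6.3 percentage points higher from compound 2 to compound 4 (within the scatter), unlike the methoxy-for-chloro step on the thiadiazole compounds, a number 23 percentage points lower from compound 1 to compound 3 (beyond the scatter), although the halogens differ. No evidence here accounts for this dependence on the sulfur substituent. From the compounds shown here alone, whether an amine on the pyrimidin-2-yl would restore the effect remains open, as does whether a longer chain on the sulfur would keep it.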